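Chain length in the hydroxycarbamoyl series: compound 3 to compound 4

The compounds below may be only part of what the source reports. "The series", "measured", "known", "first", "only" and "open" are said of these compounds alone.

compound 1 `Nc1nc2cc(-c3nn(CCCCCCCCCC(=O)NO)c4ncnc(N)c34)ccc2o1`: 23100 nM
compound 2 `Nc1nc2cc(-c3nn(CCC(=O)NO)c4ncnc(N)c34)ccc2o1`: > 100000 nM (a limit, not a number)
compound 3 `Nc1nc2cc(-c3nn(CCCCC(=O)NO)c4ncnc(N)c34)ccc2o1`: 34000 nM
compound 4 `Nc1nc2cc(-c3nn(CCCCCCCCC(=O)NO)c4ncnc(N)c34)ccc2o1`: not yet measured

In a functional assay on HCT-116 cells (Homo sapiens) for inhibition, read by MTT assay, with a stated time of 72 h (a lower number here means a stronger inhibitor, a higher number a weaker inhibitor), compound 3 lies within the scatter of compound 1, with a 1.5-fold higher number from compound 1 to compound 3 (0.17 log units; within the scatter). Compound 2 gives only a limit. Against it, the step is an at least 2.9-fold lower number from compound 2 to compound 3 (0.46 log units; beyond the scatter). Compound 4 differs from compound 3 by 4-(hydroxycarbamoyl)butyl in place of hydroxycarbamoyl on a saturated chain carbon, four bonds along the chain from an aromatic nitrogen, on a saturated chain carbon, four bonds along the chain from an aromatic nitrogen. Its chain is longer than that of compound 3 and shorter than that of compound 1, and a 1.5-fold higher number from compound 1 to compound 3 (0.17 log units; within the scatter) spans that range without leaving the scatter. The expected result is a 1.3-fold lower number from compound 3 to compound 4 (0.10 log units; within the scatter), so no step beyond the scatter is anticipated. For compound 4 the estimate is 27000 nM, with an expected range of 12000 nM to 60000 nM.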

Compound 4, half-maximal inhibitory concentration: 2980 nM
Compound 4: the middle estimate sits 9.1-fold (0.96 log units) above what was measured, outside the stated range (below it).
By their numbers in this assay, from the lowest: compound 4; then compounds 1 and 3 (each within the scatter of the next). At a limit, above all of these: compound 2.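

In this assay, 4-(hydroxycarbamoyl)butyl in place of hydroxycarbamoyl at this position gives an 11-fold lower number from compound 3 to compound 4 (1.06 log units; beyond the scatter), so chain length matters here, which compounds 1 and 3 alone did not reveal. A still longer chain does not carry the gain further, with a 7.8-fold lower number from compound 1 to compound 4 (0.89 log units; beyond the scatter), so the response is not a steady rise with length. Compound 2 gives only a limit, so an at least 33-fold lower number from compound 2 to compound 4 (1.52 log units; beyond the scatter) is a bound: the limit of > 100000 nM in this assay, at which 1 of the 4 values shown sits.

As far as these compounds go, whether the gain survives with a carboxylic acid in place of the hydroxycarbamoyl end group remains open. From the compounds shown here alone, how narrow the best chain length is also remains open.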